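From compound 3 to compound 4: an expected step down

The source may hold more compounds than are shown below. What is called first, only, known or untested is meant among the compounds shown, and "the series" means these compounds.

In an ADME assay on MT4 cells (Homo sapiens) for cytotoxicity, read by MTT assay (a lower number here means that less compound is tolerated, a higher number that more compound is tolerated), compound 3 `Cc1cc(C)cc(S(=O)(=O)c2c(C(=O)NCc3cc(O)ncn3)[nH]c3ccc(Cl)cc23)c1` gives > 53000 nM, which is a limit of the assay and not a number. Compound 1 `Cc1cc(C)cc(S(=O)(=O)c2c(C(=O)Nc3ccccc3O)[nH]c3ccc(Cl)cc23)c1` gives 19700 nM and compound 2 `Cc1cc(C)cc(S(=O)(=O)c2c(C(=O)NCc3cccc(O)c3)[nH]c3ccc(Cl)cc23)c1` gives 27000 nM. The gap is a 1.4-fold higher number from compound 1 to compound 2 (0.14 log units; within the scatter). Compound 4 `Cc1cc(C)cc(S(=O)(=O)c2c(C(=O)NCC(=O)NCc3cccc(O)c3)[nH]c3ccc(Cl)cc23)c1` has (3-hydroxybenzyl)carbamoyl in place of 6-hydroxypyrimidin-4-yl on a saturated chain carbon bound to an amide-type nitrogen. Among the compounds with values here, two measured steps bear on this change: an at least 1.9-fold higher number from compound 2 to compound 3 (0.29 log units; that floor lies within the scatter), and an at least 2.6-fold higher number from compound 1 to compound 3 (0.42 log units; beyond the scatter). Compound 4 shares the 3-hydroxybenzyl group of compound 2, so a modest move to a lower number in this assay is expected. The estimated step is an at least 1.7-fold lower number from compound 3 to compound 4 (0.24 log units; that floor lies within the scatter). For compound 4 the expected value is 30000 nM, with an estimated range of 13000 nM to 60000 nM.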

Compound 4, half-maximal cytotoxic concentration: > 47500 nM
Compound 4: no number, only a limit; the forecaster's own chance of this, stated with the estimate: 20%; middle value at least 1.5-fold (0.19 log units) away from the limit.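

In this assay compound 4 ends at a limit of the assay and not at a number: the limit of > 47500 nM in this assay, at which 1 of the 4 values shown sits. With (3-hydroxybenzyl)carbamoyl on the saturated chain carbon bound to an amide-type nitrogen, the series shows an at least 1.7-fold higher number from compound 2 to compound 4 (0.24 log units; that floor lies within the scatter), and an at least 2.4-fold higher number from compound 1 to compound 4 (0.38 log units; beyond the scatter). The step between compound 3 and compound 4 cannot be read, so 6-hydroxypyrimidin-4-yl and (3-hydroxybenzyl)carbamoyl cannot be ranked at this position.

Where compound 3 and compound 4 would read as numbers remains open. Also open, on these data alone, is whether a carboxylic acid or an amine on the same chain carbon would end at a limit too.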